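From Pyridin-3-yl to Phenyl in Compound 1

A few compounds are considered here, and "the series" means these few. Any claim that something is new, unique, unknown or untested is made for them only; others in the source may bear on it.

Three compounds sharing one core were tested in an assay on isolated protein for inhibition of DNA topoisomerase 1 (Homo sapiens), with a stated time of 30 min, tested at 100 uM; a higher number here means a stronger effect of the compound at the concentration tested, a lower number a weaker effect. Compound 1 `Oc1ccc(-c2cc(-c3ccc(Cl)cc3)nc(-c3cccnc3)c2)cc1` gives 18.8%. Compound 2 `Oc1cccc(-c2cc(-c3ccc(Cl)cc3)nc(-c3cccnc3)c2)c1`, which carries 3-hydroxyphenyl in place of 4-hydroxyphenyl on an aromatic carbon, gives 2.8%; compound 3 `Oc1ccc(-c2cc(-c3cccnc3)nc(-c3cccc(Cl)c3)c2)cc1`, which carries 3-chlorophenyl in place of 4-chlorophenyl on an aromatic carbon, gives 55.2%. Compound 1 therefore stands second highest of the three, with a number 16 percentage points lower from compound 1 to compound 2 (beyond the scatter) and a number 36.4 percentage points higher from compound 1 to compound 3 (beyond the scatter).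

Compound 4 `Oc1ccc(-c2cc(-c3ccccc3)nc(-c3ccc(Cl)cc3)c2)cc1` has not yet been measured. It differs from compound 1 in one place: phenyl in place of pyridin-3-yl on an aromatic carbon. Neither measured step touches this group; both alter the hydroxyphenyl or the chlorophenyl group, not the pyridin-3-yl one. Those steps show that the read-out responds to such changes, but they give no direct guide to exchanging pyridin-3-yl for phenyl. For the measured compounds named here, with no close precedent, the expectation for compound 4 is a small step, a number 1.2 percentage points higher from compound 1 to compound 4 (within the scatter), not clearly beyond the scatter. Compound 4 is therefore estimated at 20%, with a range from 0% to 45%.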

Compound 4, a percentage reported as inhibition, at one concentration (the size of the read-out at that concentration, not a potency): 68%
Estimate against measurement, compound 4: 48 percentage points below; measured number above the stated range.
By their numbers in this assay, from the lowest: compound 2; then compound 1; then compound 3; then compound 4.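

In this assay, phenyl in place of pyridin-3-yl gives a number 49.2 percentage points higher from compound 1 to compound 4 (beyond the scatter) on an aromatic carbon next to the ring nitrogen of the shared core. The earlier steps shown here touched only the hydroxyphenyl and chlorophenyl groups, whereas this one shows that the read-out also responds strongly at this third position. The change is small in structure, since both groups are six-membered aromatic rings and only the ring nitrogen of pyridin-3-yl, with its hydrogen-bond acceptor, is lost, yet nothing available explains the rise.

As far as these compounds go, it remains open whether an aromatic ring is needed at this position, or whether a morpholine, a dimethylamino group or a short alkyl chain would serve there too. Also unresolved is how phenyl here would combine with the 3-chlorophenyl group of compound 3.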